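A few compounds are considered here, and "the series" means these few. Any claim that something is new, unique, unknown or untested is made for them only; others in the source may bear on it.

Measured so far:
- compound 1 `CN(C)C(=O)c1cc2cnc(Nc3ccc(NC(=O)C4(C(=O)Nc5cccc(Cl)c5)CC4)cc3)nc2n1C1CCCC1`: 47.9%
- compound 2 `CN(C)C(=O)c1cc2cnc(Nc3ccc(NC(=O)C4(C(=O)Nc5cccc(Br)c5)CC4)cc3)nc2n1C1CCCC1`: 46.6%

Within the data shown here, in a functional assay on NCI-H1299 cells (Homo sapiens) for inhibition, read by CCK-8 assay, with a stated time of 72 h, tested at 1 uM (on this read-out higher numbers stand for more inhibition of growth at the one concentration tested and lower numbers for less inhibition of growth), compound 2 gives 46.6% and stands level with compound 1, the only other measured compound. Compound 3 `CN(C)C(=O)c1cc2cnc(Nc3ccc(NC(=O)C4(C(=O)Nc5ccccc5)CC4)cc3)nc2n1C1CCCC1` has not yet been measured. Its change from compound 2 is hydrogen in place of bromo on an aromatic carbon.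

Among the measured compounds shown here, only one measured step bears on this: bromo in place of chloro on an aromatic carbon, which gave a number 1.3 percentage points lower from compound 1 to compound 2 (within the scatter). For the measured compounds named here, that step exchanges one halogen for another, and no measured compound lacks the halogen, so the guidance is thin. No change beyond the scatter is therefore expected, though the uncertainty is wide. The expected step is a number 2.6 percentage points lower from compound 2 to compound 3 (within the scatter). Compound 3 is estimated at 44%, with an expected range from 30% to 58%.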

Compound 3, percent growth inhibition at one concentration: 71.2%
Compound 3: the middle estimate sits 27.2 percentage points below what was measured; measured number above the stated range.
By their numbers in this assay, from the lowest: compounds 2 and 1 (each within the scatter of the next); then compound 3.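

In this assay, what matters at this place on the six-membered aromatic ring is whether a halogen is present at all, not which halogen it is: the number is a number 24.6 percentage points higher from compound 2 to compound 3 (beyond the scatter) and a number 23.3 percentage points higher from compound 1 to compound 3 (beyond the scatter). Compounds 1 and 2 both carry a halogen and stand within the scatter of each other, so they could not reveal this; compound 3, with hydrogen there, stands beyond the scatter of both. Nothing shown gives a measured reason for this gain.

From the compounds shown here alone, it remains open whether any group at this place lowers the number or only chloro and bromo do, as a fluoro, a methyl, a methoxy or an amine could tell. The compounds shown also leave open whether the same change would count for as much in a series with a different group in place of the cyclopentyl.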